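Replacing an Octyl Chain with a Bromophenyl Ring

A few compounds are considered here, and "the series" means these few. Any claim that something is new, unique, unknown or untested is made for them only; others in the source may bear on it.

Among the measured compounds shown here, in an ADME assay on WI-38 cells (Homo sapiens) for cytotoxicity, read by MTT assay, with a stated time of 3 days (a higher number here means a weaker inhibitor, a lower number a stronger inhibitor), compound 2 `CCCCCCCCC#Cc1cn(C/C=C\CN2C(=O)c3ccccc3C2=O)c(=O)[nH]c1=O` gives 49000 nM, the only number among the values shown. Compound 1 `Cc1ccc(C#Cc2cn(C/C=C\CN3C(=O)c4ccccc4C3=O)c(=O)[nH]c2=O)cc1` gives a limit rather than a number, > 100000 nM (the limit of > 100000 nM in this assay, at which 1 of the 2 values shown sits). For the measured compounds named here, the one measured step, an at least 2.0-fold lower number from compound 1 to compound 2 (0.30 log units; that floor lies within the scatter), was octyl in place of 4-methylphenyl on a triple-bonded carbon. Compound 3 `O=C1c2ccccc2C(=O)N1C/C=C\Cn1cc(C#Cc2ccc(Br)cc2)c(=O)[nH]c1=O` reverses that kind of change: 4-bromophenyl in place of octyl on a triple-bonded carbon. Because the step of an at least 2.0-fold lower number from compound 1 to compound 2 (0.30 log units; that floor lies within the scatter) ran toward a lower number when an octyl chain replaced an aryl ring, the return to an aryl ring is expected to give a higher number, plausibly of at least a similar size and quite possibly past the limit, although 4-bromophenyl is not the same group as 4-methylphenyl. Compound 3 is therefore estimated at 100000 nM, with a range of 40000 nM to 250000 nM, meaning an expected step of a 2.0-fold higher number from compound 2 to compound 3 (0.31 log units; beyond the scatter).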

Compound 3, half-maximal inhibitory concentration: 47000 nM
Estimate against measurement, compound 3: 2.1-fold (0.33 log units) above; the measured number falls inside the stated range.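

In this assay, 4-bromophenyl in place of octyl on a triple-bonded carbon gives a 1.0-fold lower number from compound 2 to compound 3 (0.02 log units; within the scatter), so among these compounds a ring at this position is not told apart from a straight chain. The substituent on the ring does register: bromo in place of methyl on an aromatic carbon gives an at least 2.1-fold lower number from compound 1 to compound 3 (0.32 log units; beyond the scatter), which shows that compound 1 and compound 3 separate even though both carry an aromatic ring here. Compound 1 stands at a limit and not at a number, so the true size of that step stays unknown: the limit of > 100000 nM in this assay, at which 1 of the 3 values shown sits.

The compounds shown leave open whether a chlorine or a methoxy group on the ring would fall with the bromo or the methyl compound. They also leave open how a shorter chain, or an amine at the end of the chain, would read in this assay.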